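This account rests on a few compounds, and the source may have more. Where it says the series, first, only, none or still open, it means among the compounds named here.

In a functional assay on MCF7 cells (Homo sapiens) for cytotoxicity, read by MTT assay, with a stated time of 48 h (on this read-out higher numbers stand for weaker inhibition and lower numbers for stronger inhibition), three compounds on one shared core have been measured so far. Compound 1 (`C=C1CCC[C@]2(C)CCC(c3cn(-c4ccc(OC)cc4)nn3)=CC[C@@]12C`) gives 118000 nM and compound 2 (`C=C1CCC[C@]2(C)CCC(c3cn(-c4ccc(I)cc4)nn3)=CC[C@@]12C`) gives 162000 nM as its number, and a 1.4-fold higher number from compound 1 to compound 2 (0.14 log units; within the scatter) separates the two. Compound 3 (`C=C1CCC[C@]2(C)CCC(c3cn(-c4ccccc4C(C)=O)nn3)=CC[C@@]12C`) gives 29900 nM and stands lowest of the three, beyond the scatter from both others.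

The next compound to be read is compound 4 (`C=C1CCC[C@]2(C)CCC(c3cn(-c4ccc(Cl)cc4)nn3)=CC[C@@]12C`). The change from compound 3 is 4-chlorophenyl in place of 2-acetylphenyl on an aromatic nitrogen and in words it puts 4-chlorophenyl in place of 2-acetylphenyl on an aromatic nitrogen. Within the data shown here, no compound with 4-chlorophenyl has been measured, so the guidance is indirect. The closest measured steps are a 3.9-fold lower number from compound 1 to compound 3 (0.60 log units; beyond the scatter) and a 5.4-fold lower number from compound 2 to compound 3 (0.73 log units; beyond the scatter) and both are modest. Each brings in 2-acetylphenyl on that aromatic nitrogen, whereas compound 4 gives it up and, like compound 1 and compound 2, carries a single group at the 4 position of the phenyl. Those two steps, run backwards, point to a modest move towards weaker inhibition. The expected change is a 4.0-fold higher number from compound 3 to compound 4 (0.60 log units; beyond the scatter) by this estimate. Compound 4 is estimated at 120000 nM with an expected range from 55000 nM to 240000 nM as its likely reading.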

Compound 4, half-maximal inhibitory concentration: 35100 nM
Beside the measured number, compound 4's estimate is 3.4-fold (0.53 log units) above it; measured number outside the range, below it.
By their numbers in this assay, from the lowest: compounds 3 and 4 (each within the scatter of the next); then compounds 1 and 2 (each within the scatter of the next).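

In this assay, the step to 4-chlorophenyl on the aromatic nitrogen gives a 1.2-fold higher number from compound 3 to compound 4 (0.07 log units; within the scatter) and so shows that the low reading at this position is not confined to 2-acetylphenyl: a phenyl without any carbonyl group reads alike. Among these compounds, it also shows that the single group on the aromatic carbon of the phenyl can move the number, since chloro in place of iodo gives a 4.6-fold lower number from compound 2 to compound 4 (0.66 log units; beyond the scatter) and chloro in place of methoxy gives a 3.4-fold lower number from compound 1 to compound 4 (0.53 log units; beyond the scatter). Iodo in place of methoxy, by contrast, gives a 1.4-fold higher number from compound 1 to compound 2 (0.14 log units; within the scatter). Nothing in the data shown explains why chloro parts from iodo and methoxy in this way.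

The compounds shown do not separate the group from its place on the phenyl, so it stays open whether 2-chlorophenyl or 4-acetylphenyl would read like compound 3 and compound 4. From the compounds shown here alone, it is also open how an amine, a carboxylic acid or a longer chain on that phenyl would read against chloro on the shared core.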